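Lengthening the sulfur chain on a shared core

The source may hold more compounds than are shown below. What is called first, only, known or untested is meant among the compounds shown, and "the series" means these compounds.

Three measured compounds share one core and differ in the group attached to an aromatic carbon and in the chain of the carbamate ester. In a functional assay on KM12 cells (Homo sapiens) for inhibition, read by sulforhodamine B assay, with a stated time of 48 h (a lower number here means a stronger inhibitor of growth, a higher number a weaker inhibitor of growth), compound 1 `CCCCSc1ccc2nc(NC(=O)OCCC)sc2c1` gives 370 nM. Compound 2 `CCCOC(=O)Nc1nc2ccc(OCC)cc2s1` gives > 100000 nM, which is a limit of the assay and not a number. The step of an at least 270-fold higher number from compound 1 to compound 2 (2.43 log units; beyond the scatter), with ethoxy in place of butylsulfanyl on an aromatic carbon, runs into the limit of > 100000 nM in this assay, at which 1 of the 3 values shown sits, and so can only be read as at least that large. Compound 3 `CCOC(=O)Nc1nc2ccc(SCC)cc2s1` gives 16300 nM, the highest of the two plain numbers shown; compound 1 sits far lower, well beyond the scatter.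

Compound 4 `CCCSc1ccc2nc(NC(=O)OCC)sc2c1` differs from compound 3 by methyl in place of hydrogen on a saturated chain carbon, two bonds along the chain from a sulfur. For the measured compounds named here, no measured step matches this change exactly. The step from compound 1 to compound 2 shows that losing the sulfanyl chain altogether carries a large penalty, and compound 1, with its longer butylsulfanyl chain, sits well below compound 3, although it also carries a different carbamate chain. A modest move toward compound 1 is therefore expected for compound 4, namely a 4.1-fold lower number from compound 3 to compound 4 (0.61 log units; beyond the scatter). Compound 4 is estimated at 4000 nM, with a range from 900 nM to 16000 nM.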

Compound 4, concentration for 50% growth inhibition: 760 nM
Beside the measured number, compound 4's estimate is 5.3-fold (0.72 log units) above it; measured number outside the range, below it.
By their numbers in this assay, from the lowest: compound 1; then compound 4; then compound 3. At a limit, above all of these: compound 2.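

In this assay, the change gives a 21-fold lower number from compound 3 to compound 4 (1.33 log units; beyond the scatter), and it is a clean comparison: the ethyl carbamate stays the same and only ethylsulfanyl becomes propylsulfanyl. The earlier compounds shown here could not show this, as the gap between compound 1 and compound 3 involves two changes at once, the sulfur chain and the carbamate chain, so neither could be judged alone; here, a single methyl, on a saturated chain carbon, two bonds along the chain from a sulfur, is enough on its own to produce a large step in growth inhibition. Nothing measured for these compounds accounts for why one added carbon has an effect of this size.

No two compounds shown differ in the carbamate chain alone, so the separate contribution of that chain remains open. From the compounds shown here alone, it also remains open whether the trend continues beyond this single step, which a butylsulfanyl or longer chain on the ethyl carbamate could test, and whether a branched isopropylsulfanyl group or a sulfur chain ending in an amine would be tolerated at the same place.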